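The compounds below may be only part of what the source reports. "The series", "measured", "known", "first", "only" and "open" are said of these compounds alone.

Measured so far:
- compound 1, `CCCOc1cccc(/C=N/n2c(-c3ccccc3)nc3ccccc3c2=O)c1`: 100 mg/kg in a functional assay on the whole organism (strain albino CF-1) with Mus musculus as the target, in the maximal electroshock model, with a stated time of 0.5 h; a lower number here means that less compound is needed, a higher number that more compound is needed for the effect
- compound 2, `C=CCCOc1cccc(/C=N/n2c(-c3ccccc3)nc3ccccc3c2=O)c1`: 300 mg/kg in this assay
- compound 3, `CCOc1cccc(/C=N/n2c(-c3ccccc3)nc3ccccc3c2=O)c1`: 100 mg/kg in this assay

Compound 3 stands level with compound 1 at the digits shown, and together these two have the lowest numbers of the three; the step of no change at the digits printed from compound 1 to compound 3 (within the scatter) lies within the scatter. Compound 2 stands apart: a 3.0-fold lower number from compound 2 to compound 3 (0.48 log units; beyond the scatter) and a 3.0-fold higher number from compound 1 to compound 2 (0.48 log units; beyond the scatter) both exceed the scatter, though only modestly.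

Compound 4, `CCCCOc1cccc(/C=N/n2c(-c3ccccc3)nc3ccccc3c2=O)c1`, is not yet measured. It differs from compound 3 as follows: ethyl in place of hydrogen on a saturated chain carbon, two bonds along the chain from an oxygen on an aromatic ring. Among the measured compounds shown here, two measured steps bear on this. The step of no change at the digits printed from compound 1 to compound 3 (within the scatter) shows that shortening the chain by one carbon changed nothing; the step of a 3.0-fold higher number from compound 1 to compound 2 (0.48 log units; beyond the scatter) shows that a longer, unsaturated chain raised the number modestly. Compound 4 carries a chain of the same length as compound 2 but saturated, so a small rise or no change beyond the scatter in this assay is expected, with the rise seen for compound 2 as the upper bound. For compound 4 the expected result is 150 mg/kg, in the range 100 mg/kg to 300 mg/kg, which is an estimated step of a 1.5-fold higher number from compound 3 to compound 4 (0.18 log units; within the scatter).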

Compound 4, minimum effective dose: 300 mg/kg
The estimate for compound 4 lay 2.0-fold (0.30 log units) below the measured number, within the range that was stated.
By their numbers in this assay, from the lowest: compounds 1 and 3 (each within the scatter of the next); then compounds 2 and 4 (each within the scatter of the next).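

The rise in the number seen with compound 2 now also appears with a fully saturated chain: in this assay ethoxy to butoxy gives a 3.0-fold higher number from compound 3 to compound 4 (0.48 log units; beyond the scatter) at this position, and one further methyl on the propoxy chain gives a 3.0-fold higher number from compound 1 to compound 4 (0.48 log units; beyond the scatter) as well. The double bond of compound 2 therefore makes no visible difference, as ethyl in place of vinyl gives no change at the digits printed from compound 2 to compound 4 (within the scatter) here. Across these four compounds, the ethoxy and propoxy chains of compounds 3 and 1 share the lower level, while the two longer chains of compounds 2 and 4 share the higher one, so the change comes with the step from propoxy to butoxy rather than with saturation. Nothing given here explains this step in the number.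

The compounds shown leave open whether the number keeps rising with a longer chain such as hexyloxy, or stays at the level of compound 4. They also leave open how a shorter methoxy group, a branched isopropoxy group or a chain ending in an amine or a carboxylic acid would read in this assay at this position.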